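Extending compound 3's aromatic group to a methoxyquinoline

The source may hold more compounds than are shown below. What is called first, only, known or untested is meant among the compounds shown, and "the series" means these compounds.

Measured compounds:
compound 1 `COc1ccc(Cl)cc1C(=O)NCCC1CCN(S(=O)(=O)NC(=O)NC2CCCCC2)CC1`: 25%
compound 2 `COc1ncccc1C(=O)NCCC1CCN(S(=O)(=O)NC(=O)NC2CCCCC2)CC1`: 33%
compound 3 `Cc1ncccc1C(=O)NCCC1CCN(S(=O)(=O)NC(=O)NC2CCCCC2)CC1`: 16%

In a functional assay on the whole organism (blood) with Rattus norvegicus as the target, with stated times of 24 h and 1 h, at a dose of 5 mg/kg by the intraperitoneal route (a lower number here means a weaker effect, a higher number a stronger effect of the compound at the dose given), compound 3 gives 16%, the lowest of the three numbers. Its nearest neighbour is compound 1 with 25%, a gap within the scatter; the step of a number 17 percentage points lower from compound 2 to compound 3 (beyond the scatter) is the only one beyond the scatter among the three, and it comes from methyl in place of methoxy on an aromatic carbon.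

Compound 4 `COc1ccc2nccc(C(=O)NCCC3CCN(S(=O)(=O)NC(=O)NC4CCCCC4)CC3)c2c1` has not yet been measured. It differs from compound 3 by 6-methoxyquinolin-4-yl in place of 2-methylpyridin-3-yl on a carbonyl carbon. Of the measured steps, a number 17 percentage points lower from compound 2 to compound 3 (beyond the scatter) bears on it most. The entering group restores a methoxy. The step of a number 9 percentage points lower from compound 1 to compound 3 (within the scatter) is within the scatter. Going by the values given here, no measured step covers the second aromatic ring, so that part is unknown.

A modest rise is therefore expected, roughly a number 12 percentage points higher from compound 3 to compound 4 (beyond the scatter). Compound 4 is estimated at 28%, with a range from 10% to 50%.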

Compound 4, a percentage reported as activity, at one dose (the size of the read-out at that dose, not a potency): 15%
For compound 4 the middle estimate is 13 percentage points above the measured one; measured number inside the range.
By their numbers in this assay, from the lowest: compounds 4, 3, 1 and 2 (each within the scatter of the next, the first and the last beyond it).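

In this assay, the methoxy on 6-methoxyquinolin-4-yl did not restore the higher number of compound 2: this group in place of 2-methoxypyridin-3-yl gives a number 18 percentage points lower from compound 2 to compound 4 (beyond the scatter), so on this carbonyl carbon a methoxy alone does not secure that read-out. The same group in place of 2-methylpyridin-3-yl gives a number 1 percentage points lower from compound 3 to compound 4 (within the scatter), and in place of 5-chloro-2-methoxyphenyl it gives a number 10 percentage points lower from compound 1 to compound 4 (within the scatter), so the second aromatic ring and the larger group leave compound 4 within the scatter of both compound 3 and compound 1. No measurement at hand explains this result.

The compounds shown do not separate the contribution of the second ring from that of the methoxy, since the plain quinolin-4-yl group is absent from them. From the compounds shown here alone, whether an amine or a carboxylic acid on the aromatic group would reach or pass the number of compound 2 also remains open.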